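A few compounds are considered here, and "the series" means these few. Any claim that something is new, unique, unknown or untested is made for them only; others in the source may bear on it.

Two compounds of the shared core have been run so far. In a functional assay on MCF7 cells (Homo sapiens) for antiproliferative activity, read by MTT assay, with a stated time of 24 h, tested at 50 uM (a lower number here means a stronger effect, a higher number a weaker effect of the compound at the concentration tested), compound 1 `OC(CCn1nc2c(Br)c(Br)c(Br)c(Br)c2n1)c1cccc(Br)c1` gives 14% and compound 2 `OC(CCn1nc2c(Br)c(Br)c(Br)c(Br)c2n1)c1ccc(F)cc1` gives 16%, the top of the two numbers, though a number 2 percentage points higher from compound 1 to compound 2 (within the scatter) leaves the pair within the scatter. Compound 3 `COc1cccc(C(O)CCn2nc3c(Br)c(Br)c(Br)c(Br)c3n2)c1` carries 3-methoxyphenyl in place of 4-fluorophenyl on a saturated chain carbon bound to an oxygen on a saturated carbon and a saturated chain carbon. Among the measured compounds shown here, the only step bearing on it is the one from compound 1 to compound 2, a change at the same place that stayed within the scatter, so no step beyond the scatter is expected here either. Compound 3 is therefore estimated at 16% in this assay, with a range of 7% to 27%. The expected step is no change at the digits printed from compound 2 to compound 3 (within the scatter).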

Compound 3, a percentage reported as activity, at one concentration (the size of the read-out at that concentration, not a potency): 22%
Estimate against measurement, compound 3: 6 percentage points below; the measured number falls inside the stated range.
By their numbers in this assay, from the lowest: compounds 1, 2 and 3 (each within the scatter of the next).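

In this assay the change to 3-methoxyphenyl in place of 4-fluorophenyl stays within the scatter (a number 6 percentage points higher from compound 2 to compound 3 (within the scatter)), as does methoxy in place of bromo on an aromatic carbon (a number 8 percentage points higher from compound 1 to compound 3 (within the scatter)). This position on the saturated chain carbon therefore also tolerates an oxygen-bearing aryl group, which the halogen-only pair of compound 1 and compound 2 did not show. No evidence on any cause for these steps is at hand.

Open, from the compounds shown here alone, is whether an amine or a carboxylic acid on this phenyl ring would give a step beyond the scatter. Going by these compounds, a longer chain in place of the saturated chain is equally open.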